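A few compounds are considered here, and "the series" means these few. Any claim that something is new, unique, unknown or untested is made for them only; others in the source may bear on it.

Measured so far:
compound 1 `Cc1ccc(NC(=O)N[C@@H](C)c2ccccc2)cc1` gives 100% in an ADME assay on the whole organism with Oryza sativa as the target, tested at 10 uM; on this read-out higher numbers stand for a weaker effect at the one concentration tested and lower numbers for a stronger effect;
compound 2 `CCCc1ccc(NC(=O)N[C@@H](C)c2ccccc2)cc1` gives 73%;
compound 3 `CC(=O)c1ccc(NC(=O)N[C@H](C)c2ccccc2)cc1` gives 84%.

Compound 3 stands second highest of the three numbers in this assay: its value lies below that of compound 1 and above that of compound 2, both gaps beyond the scatter. Compound 4 `CC(=O)c1ccc(NC(=O)N[C@@H](C)c2ccccc2)cc1` is its mirror partner: the two compounds have the same atoms and bonds and differ only in configuration as drawn: 1 of 1 stereo elements differ; a stereocentre at a saturated chain carbon is drawn R in compound 3 and S in compound 4. Among the compounds with values here, the one measured step, a number 27 percentage points lower from compound 1 to compound 2 (beyond the scatter), concerns a change in a substituent, not a change of configuration, so it does not bear on this step. Within the data shown here, no measured pair shows what inverting this stereocentre does. The expectation is therefore a step of no size beyond the scatter, no change at the digits printed from compound 3 to compound 4 (within the scatter). Compound 4 is estimated at 84%, within 66% to 100%.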

Compound 4, a percentage reported as activity, at one concentration (the size of the read-out at that concentration, not a potency): 96%
For compound 4 the middle estimate is 12 percentage points below the measured one; the measured number falls inside the stated range.
By their numbers in this assay, from the lowest: compound 2; then compound 3; then compounds 4 and 1 (each within the scatter of the next).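

The stereocentre at the saturated chain carbon matters in this assay: inverting it gives a number 12 percentage points higher from compound 3 to compound 4 (beyond the scatter). This step can come only from the inversion, because nothing else changes: the fact that compounds 3 and 4 differ only in the configuration as drawn. On the aromatic carbon, acetyl in place of methyl gives a number 4 percentage points lower from compound 1 to compound 4 (within the scatter), while acetyl in place of propyl gives a number 23 percentage points higher from compound 2 to compound 4 (beyond the scatter).

On these data alone, it remains open whether the same inversion would shift the number with methyl or propyl on the aromatic carbon. As far as these compounds go, what an amine or a carboxylic acid at that place would give also remains open.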